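The source may hold more compounds than are shown below. What is called first, only, known or untested is meant among the compounds shown, and "the series" means these compounds.

Working notes on the series, read in a functional assay on MDA-MB-453 cells (Homo sapiens) for antiproliferative activity; a higher number here means a weaker inhibitor of growth, a lower number a stronger inhibitor of growth. Compound 1 `CCCCCCNC(=O)c1cc(CCc2cc(O)ccc2O)ccc1O` gives 3200 nM, and compound 3 `COc1ccc(OC)c(C#Cc2ccc(OC)c(C(=O)O)c2)c1` gives 8800 nM, the higher of the two actual numbers. Compound 2 `CCCCCCNC(=O)c1cc(C#Cc2cc(OC)ccc2OC)ccc1OC` reports only a limit of the assay, > 100000 nM.

The next structure is compound 4 `COC(=O)c1cc(C#Cc2cc(OC)ccc2OC)ccc1OC`, which differs from compound 3 as follows: methyl in place of hydrogen on an oxygen next to a carbonyl group. This is methyl in place of hydrogen on an oxygen next to a carbonyl group, or carboxy to methoxycarbonyl.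

Within the data shown here, one measured step bears on this change: an at least 11-fold lower number from compound 2 to compound 3 (1.05 log units; beyond the scatter), with hydroxy in place of hexylamino on a carbonyl carbon. That step is large, but its size is only a bound, resting on (the limit of > 100000 nM in this assay, at which 1 of the 3 values shown sits). Among the measured compounds shown here, no measured step covers a methyl at this oxygen, so the transfer is loose.

Compound 4, like compound 2, has no hydroxy on that carbonyl carbon, so part of an at least 11-fold lower number from compound 2 to compound 3 (1.05 log units; beyond the scatter) is expected to be lost, though not all of it, given that methyl replaces only a hydrogen. The expected change is modest and towards a higher number, a 2.3-fold higher number from compound 3 to compound 4 (0.36 log units; beyond the scatter). Compound 4 is estimated at 20000 nM, with an expected range of 3000 nM to 100000 nM.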

Compound 4, concentration for 50% growth inhibition: > 100000 nM
Compound 4: only a limit was reported; the forecaster's own chance of this, stated with the estimate: 20%; at least 5.0-fold (0.69 log units) between middle value and limit.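

In this assay, adding one methyl to the carboxy group of compound 3 has a large effect, far larger than the modest shift a single-atom change might suggest: an at least 11-fold higher number from compound 3 to compound 4 (1.05 log units; beyond the scatter). Compound 4 carries no hexylamino group and still gives > 100000 nM, which is a limit of the assay. Removing hexylamino alone therefore does not restore a readable number, and among the compounds with this carbonyl group, only compound 3, with its hydrogen on this oxygen, gives one; the step from compound 2 to compound 4 cannot be read, and the step from compound 3 to compound 4 is itself only a bound: the limit of > 100000 nM in this assay, at which 2 of the 4 values shown sit.

Still open, going by these compounds, is whether a primary amide or an ethyl ester on this carbonyl carbon would read like compound 3 or like compound 4, which would show how narrowly the free carboxylic acid is required. Also open, on these data alone, is whether the carboxylic acid keeps its advantage on a core with free hydroxy groups in place of the methoxy groups, as carried by compound 1.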